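The compounds below may be only part of what the source reports. "The series", "measured", "known", "first", "only" and "open" are said of these compounds alone.

In a functional assay on NCI-H460 cells (Homo sapiens) for cytotoxicity, read by MTT assay, with a stated time of 48 h (on this read-out higher numbers stand for weaker inhibition and lower numbers for stronger inhibition), compound 1 `C=C1C(=O)O[C@H]2CC3=C[C@H](C/C(C)=C/[C@@H](OC(=O)/C=C/c4cccc(OC)c4)[C@H]12)OC3=O` gives > 10000 nM, which is a limit and not a number. Compound 3 `C=C1C(=O)O[C@H]2CC3=C[C@H](C/C(C)=C/[C@@H](OC(=O)CCl)[C@H]12)OC3=O` gives > 10000 nM, likewise only a limit, so it stands at the limit of > 10000 nM in this assay, at which 2 of the 3 values shown sit. Compound 4 `C=C1C(=O)O[C@H]2CC3=C[C@H](C/C(C)=C/[C@@H](OC(=O)C4CCC(F)(F)CC4)[C@H]12)OC3=O` differs from compound 3 by 4,4-difluorocyclohexyl in place of chloromethyl on a carbonyl carbon. The closest guide is compound 2 `C=C1C(=O)O[C@H]2CC3=C[C@H](C/C(C)=C/[C@@H](OC(=O)CCCCC)[C@H]12)OC3=O`, which carries pentyl on the same carbonyl carbon and gives 5900 nM. The measured steps offer little: there is an at least 1.6-fold higher number from compound 2 to compound 3 (0.22 log units; that floor lies within the scatter), there is an at least 1.6-fold lower number from compound 1 to compound 2 (0.22 log units; that floor lies within the scatter), and there is a step that the two limits leave unreadable from compound 1 to compound 3. In this assay, only a small move towards a lower number is therefore expected, close to the scatter. The expected step is an at least 1.4-fold lower number from compound 3 to compound 4 (0.15 log units; that floor lies within the scatter). Compound 4 is estimated at 7000 nM, with an expected range from 2500 nM to 20000 nM.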

Compound 4, half-maximal inhibitory concentration: > 10000 nM
Compound 4 ended at the assay's limit; the forecaster's own chance of this, stated with the estimate: 40%; middle value at least 1.4-fold (0.15 log units) away from the limit.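

In this assay, a six-membered ring of carbon only on this carbonyl carbon joins the 2-(3-methoxyphenyl)ethenyl and chloromethyl groups at the assay's limit: the limit of > 10000 nM in this assay, at which 3 of the 4 values shown sit.

Against pentyl, the change gives an at least 1.6-fold higher number from compound 2 to compound 4 (0.22 log units; that floor lies within the scatter), so compound 2 remains the only compound with a measured number, though this floor does not separate the two. The steps from compound 3 and compound 1 cannot be read, since both ends are limits.

From the compounds shown here alone, what stays open is whether a longer chain such as octyl, or a chain ending in an amine, would give a lower number than compound 2 in this assay.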